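The source may hold more compounds than are shown below. What is called first, only, known or untested is meant among the compounds shown, and "the series" means these compounds.

Compound 1, `CCN(Cc1ccccc1)c1cccc(C(=O)N2CCc3ccc(OS(N)(=O)=O)cc3C2)c1`: in an assay on HEK293 cells for inhibition of Steryl-sulfatase (Homo sapiens), tested at 0.1 uM (on this read-out higher numbers stand for a stronger effect at the one concentration tested and lower numbers for a weaker effect), compound 1 gives 17.3%.
Compound 2, `CN(CCCN1CCCCC1)c1cccc(C(=O)N2CCc3ccc(OS(N)(=O)=O)cc3C2)c1`: in this assay compound 2 gives 24.1%.

Within the data shown here, compound 2 holds the higher of the two numbers, yet its only neighbour, compound 1, sits close: a number 6.8 percentage points higher from compound 1 to compound 2 (within the scatter). Compound 3, `CCN(Cc1cccc(Br)c1)c1cccc(C(=O)N2CCc3ccc(OS(N)(=O)=O)cc3C2)c1`, is not yet measured. Its change from compound 2 is (3-bromobenzyl)(ethyl)amino in place of methyl(3-(piperidin-1-yl)propyl)amino on an aromatic carbon. Among the measured compounds shown here, the one measured step, from compound 1 to compound 2, touched the same position and stayed within the scatter, so no step beyond the scatter is expected in this assay for compound 3. Compound 3 is estimated at 20%, within 5% to 40%, an expected step of a number 4.1 percentage points lower from compound 2 to compound 3 (within the scatter).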

Compound 3, a percentage reported as inhibition, at one concentration (the size of the read-out at that concentration, not a potency): 20.9%
Compound 3: middle estimate off by 0.9 percentage points, on the low side, and the stated range covers the measured number.
By their numbers in this assay, from the lowest: compounds 1, 3 and 2 (each within the scatter of the next).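

In this assay, (3-bromobenzyl)(ethyl)amino in place of methyl(3-(piperidin-1-yl)propyl)amino gives a number 3.2 percentage points lower from compound 2 to compound 3 (within the scatter), so a second exchange of this whole group, now with an aromatic ring entering, also leaves the read-out unresolved. The smaller change, bromo in place of hydrogen on an aromatic carbon, gives a number 3.6 percentage points higher from compound 1 to compound 3 (within the scatter) and likewise separates nothing. No available data offer an explanation for these results. The compounds shown leave open whether a carboxylic acid or a primary amine on this aromatic carbon would move the read-out beyond the scatter.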